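A few compounds are considered here, and "the series" means these few. Any claim that something is new, unique, unknown or untested is made for them only; others in the source may bear on it.

Measured so far in an in vivo ADME assay on the whole organism (strain Sprague-Dawley) for pharmacokinetics, with Rattus norvegicus as the target; on this read-out lower numbers stand for narrower distribution and higher numbers for wider distribution into tissues:
compound 1 `CCCCCOC(=O)N1CCN(C(=O)[C@H](CCC(=O)O)NC(=O)c2cc(N3CCC(C(=O)NCC)CC3)nc(-c3ccccc3)n2)CC1` gives 0.2 L/kg;
compound 2 `CCCCCOC(=O)N1CCN(C(=O)[C@H](CCC(=O)O)NC(=O)c2cc(N3CCC(OCCO)CC3)nc(-c3ccccc3)n2)CC1` gives 0.8 L/kg.

Within the data shown here, only one step connects these two: a 4.0-fold higher number from compound 1 to compound 2 (0.60 log units; beyond the scatter). On the numbers shown, compound 2 stands highest of the two, with compound 1 the nearest and lower. Compound 3 `CCCCCOC(=O)N1CCN(C(=O)[C@H](CCC(=O)O)NC(=O)c2cc(N3CCC(C(N)=O)CC3)nc(-c3ccccc3)n2)CC1` differs from compound 2 by carbamoyl in place of 2-hydroxyethoxy on a saturated ring carbon. The step from compound 1 to compound 2 is the one that bears on this change, since carbamoyl in compound 3 is nearer in kind to the ethylcarbamoyl of compound 1 than to the 2-hydroxyethoxy that leaves compound 2. That step ran upward in this assay. Among the measured compounds shown here, exchanging the 2-hydroxyethoxy for carbamoyl is therefore expected to move the number partly back toward compound 1, though no measured pair shows this exact exchange. Compound 3 is therefore expected to show a 2.3-fold lower number from compound 2 to compound 3 (0.36 log units; beyond the scatter). The estimate for compound 3 is 0.35 L/kg, ranging from 0.15 L/kg to 0.8 L/kg.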

Compound 3, volume of distribution at steady state: 2.4 L/kg
Compound 3: middle estimate off by 6.9-fold (0.84 log units), on the low side; the measured number lies above the stated range.
By their numbers in this assay, from the lowest: compound 1; then compound 2; then compound 3.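

Hydrogen in place of ethyl on the amide-type nitrogen gives a 12-fold higher number from compound 1 to compound 3 (1.08 log units; beyond the scatter) in this assay, so the two amides do not read alike at this ring carbon, and removing the ethyl alone produces the largest step among these compounds. Carbamoyl in place of 2-hydroxyethoxy gives a 3.0-fold higher number from compound 2 to compound 3 (0.48 log units; beyond the scatter) and thus does not move the number back toward compound 1: compound 2, with its ether side chain, falls between the two amides rather than apart from them. Nothing available here explains why the amide hydrogen goes with the wider distribution.

The compounds shown leave open how the number runs with a methyl on the amide-type nitrogen, which would show whether the change follows the length of that substituent or needs its complete removal. They also leave open where a carboxylic acid or an amine on the same saturated ring carbon would fall relative to the carbamoyl of compound 3.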